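Swapping Biphenyl for Thiophene: Expected Cytotoxicity

The compounds below may be only part of what the source reports. "The series", "measured", "known", "first", "only" and "open" are said of these compounds alone.

Compound 1 `Cc1cc(C#N)cc(C)c1Oc1nc(Nc2ccc(C#N)cc2)ncc1-c1ccoc1`: 4980 nM
Compound 2 `Cc1cc(C#N)cc(C)c1Oc1nc(Nc2ccc(C#N)cc2)ncc1-c1ccc(-c2ccccc2)cc1`: > 253000 nM

In an ADME assay on MT4 cells (Homo sapiens) for cytotoxicity, read by MTT assay, with a stated time of 5 days (on this read-out lower numbers stand for higher toxicity in this test and higher numbers for lower toxicity in this test), compound 1 gives 4980 nM. Among the measured compounds shown here, for compound 2 the test reports only a limit, > 253000 nM, so its true number is unknown; this is the one value that sits at the limit of > 253000 nM in this assay, at which 1 of the 2 values shown sits. For the measured compounds named here, the single measured step, an at least 50-fold higher number from compound 1 to compound 2 (1.70 log units; beyond the scatter), is large. Compound 3 `Cc1cc(C#N)cc(C)c1Oc1nc(Nc2ccc(C#N)cc2)ncc1-c1cccs1` differs from compound 2 by thiophen-2-yl in place of 4-phenylphenyl on an aromatic carbon, again a small five-membered heteroaryl, as in compound 1. A drop of roughly that size is therefore expected, an at least 31-fold lower number from compound 2 to compound 3 (1.50 log units; beyond the scatter). Compound 3 is estimated at 8000 nM, between 2000 nM and 50000 nM.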

Compound 3, half-maximal cytotoxic concentration: 6430 nM
Compound 3: middle estimate off by 1.2-fold (0.09 log units), on the high side; the measured number falls inside the stated range.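

In this assay, thiophen-2-yl at this position gives an at least 39-fold lower number from compound 2 to compound 3 (1.59 log units; beyond the scatter), so the high number of compound 2 does not carry over to this five-membered ring. The two five-membered rings cannot be told apart here, with a 1.3-fold higher number from compound 1 to compound 3 (0.11 log units; within the scatter). The number for compound 2 remains a limit, which leaves the true size of its step unknown: the limit of > 253000 nM in this assay, at which 1 of the 3 values shown sits.

Still open, on these data alone, is whether a single phenyl ring would already raise the number, or whether only the 4-phenylphenyl group does. As far as these compounds go, how an amine or a carboxylic acid would behave at this position is also open.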